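A few compounds are considered here, and "the series" means these few. Any claim that something is new, unique, unknown or untested is made for them only; others in the source may bear on it.

The shared core carries two trifluoromethyl groups, and the three compounds differ only in the group attached to it. Compound 1 `C=CC(=O)Nc1cc(C(F)(F)F)cc(C(F)(F)F)c1` bears a (vinylcarbonyl)amino group, and in an ADME assay for pharmacokinetics, read by LC-MS, in phosphate buffer, with a stated time of 72 h, at pH 7.4, tested at 250 uM (a lower number here means that the compound disappears faster, a higher number that the compound lasts longer), compound 1 gives 1.8 h. Compound 2 `C=Cc1cc(C(F)(F)F)cc(C(F)(F)F)c1` carries a vinyl group in its place. In this assay compound 2 reaches only a limit of the assay, > 50 h, and no number. The step of an at least 27-fold higher number from compound 1 to compound 2 (1.44 log units; beyond the scatter) is thus known only as a lower bound, set by the limit of > 50 h in this assay, at which 1 of the 2 values shown sits. Compound 3 `C#Cc1cc(C(F)(F)F)cc(C(F)(F)F)c1` is not yet measured; its change is ethynyl in place of vinyl on an aromatic carbon. Going by the values given here, the single measured step replaced a different group and does not bear directly on this exchange of vinyl for ethynyl. With compound 2 already sitting at the limit, compound 3 is expected to show no step beyond the scatter, a step that the limit leaves unreadable from compound 2 to compound 3. Compound 3 is therefore estimated at 60 h, within 25 h to 150 h, most probably reported again only as a limit.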

Compound 3, half-life: > 50 h
Compound 3: only a limit was reported; the forecaster's own chance of this, stated with the estimate: 70%; the middle value is on the limit's open side.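

In this assay compound 3 gives > 50 h, a limit of the assay and not a number. Putting an ethynyl group where the (vinylcarbonyl)amino group stood gives an at least 27-fold higher number from compound 1 to compound 3 (1.44 log units; beyond the scatter), so at this place on the shared core a second small carbon group, with a triple bond rather than a double bond outside the aromatic ring, also stands well clear of compound 1. The step between the vinyl and the ethynyl compound cannot be read, and no order between them can be given, as both rest on the limit: the limit of > 50 h in this assay, at which 2 of the 3 values shown sit.

The compounds shown leave open how far beyond the limit the true half-lives of compound 2 and compound 3 lie. They also leave open how long the core would last with a propionylamino group or an amine at this place.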